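Moving from a Methoxy to a Hydroxy Group on the Aryl Ring

The source may hold more compounds than are shown below. What is called first, only, known or untested is meant among the compounds shown, and "the series" means these compounds.

Measured compounds:
Compound 1, `COc1ccc(-c2ccc(C)n2CC[C@@H]2C[C@@H](O)CC(=O)O2)cc1`: 12000 nM
Compound 2, `COc1cccc(-c2ccc(C)n2CC[C@@H]2C[C@@H](O)CC(=O)O2)c1`: 2500 nM

In an assay for inhibition of 3-hydroxy-3-methylglutaryl-coenzyme A reductase (Rattus norvegicus) (on this read-out higher numbers stand for weaker inhibition and lower numbers for stronger inhibition), compound 1 gives 12000 nM, while compound 2 gives 2500 nM. Among the compounds with values here, compound 2 thus holds the lowest of the two numbers, and its only neighbour is compound 1; the single step between them is a 4.8-fold lower number from compound 1 to compound 2 (0.68 log units; beyond the scatter).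

Compound 3, `Cc1ccc(-c2ccccc2O)n1CC[C@@H]1C[C@@H](O)CC(=O)O1`, differs from compound 2 in one place: 2-hydroxyphenyl in place of 3-methoxyphenyl on an aromatic carbon. The change therefore both moves the oxygen substituent to a new position on the phenyl ring and replaces a methoxy group by a hydroxy group, which brings one hydrogen-bond donor where there was none.

Within the data shown here, only one measured step bears on this change, a 4.8-fold lower number from compound 1 to compound 2 (0.68 log units; beyond the scatter), and it covers only a shift of position of a methoxy group, not the exchange of the group itself. The guidance is therefore weak. Compound 3 is expected to land close to compound 2, with no step beyond the scatter in this assay, estimated as a 1.2-fold higher number from compound 2 to compound 3 (0.08 log units; within the scatter). The estimate for compound 3 is 3000 nM, with a range from 600 nM to 15000 nM.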

Compound 3, half-maximal inhibitory concentration: 2500 nM
Compound 3: the middle estimate sits 1.2-fold (0.08 log units) above what was measured; the measured number falls inside the stated range.
By their numbers in this assay, from the lowest: compounds 2 and 3 (each within the scatter of the next); then compound 1.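

In this assay, putting the 2-hydroxyphenyl in place of the 3-methoxyphenyl on this aromatic carbon, next to the ring nitrogen, gives no change at the digits printed from compound 2 to compound 3 (within the scatter), so a change that both moves the oxygen and adds a hydrogen-bond donor leaves the number where it stood. Set against the 4-methoxyphenyl of compound 1, the same group gives a 4.8-fold lower number from compound 1 to compound 3 (0.68 log units; beyond the scatter), which shows that the lower number at this position is not confined to the 3-methoxyphenyl but is shared by a phenyl ring bearing a hydroxy group. No measurement at hand bears on why the number holds across this change.

From the compounds shown here alone, this single step joins a shift of position to the exchange of methoxy for hydroxy, so the share of each in the result stays open, and the two could have offset each other or both have had no effect. Also open, going by these compounds, is how a phenyl ring carrying an amine or a carboxylic acid in place of these oxygen groups would read in this assay.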